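The source may report more compounds than this note shows. Statements on the series, on what has been measured and on what is new or still open speak of the compounds shown alone.

Three compounds share one core and differ only in the group carried on an amine nitrogen in a ring. Compound 1 `CCN(CC)c1ccc2cc(C(=O)c3ccc(N4CCN(C(=O)COc5ccc(Cl)cc5Cl)CC4)cc3)oc2c1` gives 30 nM in a functional assay on HeLa cells (Homo sapiens) for cytotoxicity, read by MTT assay, with a stated time of 48 h; on this read-out higher numbers stand for weaker inhibition and lower numbers for stronger inhibition. Compound 2 `CCN(CC)c1ccc2cc(C(=O)c3ccc(N4CCN(S(=O)(=O)c5ccc([N+](=O)[O-])cc5)CC4)cc3)oc2c1` reaches only a limit in this assay, > 40000 nM, and no number (the limit of > 40000 nM in this assay, at which 1 of the 3 values shown sits). Compound 3 `CCN(CC)c1ccc2cc(C(=O)c3ccc(N4CCN(S(=O)(=O)c5ccc(Br)c(F)c5)CC4)cc3)oc2c1` gives 20700 nM in this assay. Going by the values given here, of the two numbers known, compound 3 holds the higher one: there is a 690-fold higher number from compound 1 to compound 3 (2.84 log units; beyond the scatter). The comparable change gives an at least 1300-fold higher number from compound 1 to compound 2 (3.12 log units; beyond the scatter), while an at least 1.9-fold lower number from compound 2 to compound 3 (0.28 log units; that floor lies within the scatter) is small.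

Compound 4 `CCN(CC)c1ccc2cc(C(=O)c3ccc(N4CCN(C(C)=O)CC4)cc3)oc2c1` is the next member. Its change is acetyl in place of (4-bromo-3-fluorophenyl)sulfonyl on an amine nitrogen in a ring. The bearing steps are those from compound 1 to compound 2 and from compound 1 to compound 3, both large, and both point the same way: a sulfonyl on the ring nitrogen brings a much higher number than a carbonyl. Compound 4 returns to a carbonyl, yet a far smaller one than in compound 1, so only part of that large step is expected to reverse, as a 6.9-fold lower number from compound 3 to compound 4 (0.84 log units; beyond the scatter). Compound 4 is therefore estimated at about 3000 nM, between 300 nM and 30000 nM.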

Compound 4, half-maximal inhibitory concentration: 5150 nM
The estimate for compound 4 lay 1.7-fold (0.23 log units) below the measured number; the measured number falls inside the stated range.
By their numbers in this assay, from the lowest: compound 1; then compound 4; then compound 3. At a limit, above all of these: compound 2.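

In this assay, acetyl in place of either sulfonyl group moves the number the same way, with a 4.0-fold lower number from compound 3 to compound 4 (0.60 log units; beyond the scatter) and an at least 7.7-fold lower number from compound 2 to compound 4 (0.89 log units; beyond the scatter), and the second of these is only a floor. Compound 2 has no exact number, only a limit: the limit of > 40000 nM in this assay, at which 1 of the 4 values shown sits.

A carbonyl on the ring nitrogen is still not enough by itself, since hydrogen in place of 2,4-dichlorophenoxy gives a 170-fold higher number from compound 1 to compound 4 (2.23 log units; beyond the scatter), so most of the low number of compound 1 goes with that group.

These compounds cannot separate the contribution of the chlorines from that of the phenoxy group, which an unsubstituted phenoxy on the same chain would address. Methanesulfonyl on the ring nitrogen would likewise show whether the high numbers follow the sulfonyl itself or its aryl ring.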